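Propyl in place of methoxycarbonyl: working notes

The source may hold more compounds than are shown below. What is called first, only, known or untested is meant among the compounds shown, and "the series" means these compounds.

Measured so far in a functional assay on the whole organism (brain) with Mus musculus as the target; a lower number here means that less compound is needed, a higher number that more compound is needed for the effect:
- compound 1 (`COC(=O)c1ccc(OCCc2c[nH]cn2)cc1`) gives > 3 mg/kg (a limit)
- compound 2 (`Fc1c(F)c(F)c(OCCc2c[nH]cn2)c(F)c1F`) gives 10 mg/kg (a full number)

In this assay compound 1 is known only as a limit (> 3 mg/kg) and not as a number. Compound 3 (`CCCc1ccc(OCCc2c[nH]cn2)cc1`) has propyl in place of methoxycarbonyl on an aromatic carbon. Going by the values given here, no measured step shows what this change does. In this assay no step beyond the scatter is expected, in either direction. The expected step is small (a step that the limit leaves unreadable from compound 1 to compound 3). For compound 3 the estimate is 4 mg/kg with an expected range from 1.2 mg/kg to 12 mg/kg (not yet measured).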

Compound 3, dose for half-maximal effect: 1.6 mg/kg
Compound 3: middle estimate off by 2.5-fold (0.40 log units), on the high side; low and high end bracket the measured number.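

The change to propyl gives an at least 1.8-fold lower number from compound 1 to compound 3 (0.27 log units; that floor lies within the scatter) in this assay. Propyl carries no hydrogen-bond acceptors and no double bond, yet compound 3 gives 1.6 mg/kg, so a carbonyl at this position is not required for a full number in this series. The true size of the step stays unread, since compound 1 is known only as a limit: the limit of > 3 mg/kg in this assay, at which 1 of the 3 values shown sits.

From the compounds shown here alone, whether a longer chain such as butyl, or an amine, at this position would move the number beyond the scatter remains open. Going by these compounds, a carboxylic acid in the same place is equally open.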